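The source may report more compounds than this note shows. Statements on the series, on what has been measured and on what is new or still open speak of the compounds shown alone.

Measured in a functional assay on B16 cells (Mus musculus) for cytotoxicity, read by MTT assay, with a stated time of 48 h; on this read-out higher numbers stand for weaker inhibition and lower numbers for stronger inhibition:
Compound 1 `COc1cccc(Cn2cc(-c3ccc4ccccc4c3)nn2)c1` gives > 100000 nM, which is a limit of the assay rather than a number.
Compound 2 `CC1(C)OC[C@H](Cn2cc(-c3ccc4ccccc4c3)nn2)O1` gives 12000 nM.
Compound 3 `COc1ccc(C(O)c2cn(C[C@H]3COC(C)(C)O3)nn2)cc1` gives > 100000 nM, which is a limit of the assay rather than a number.

The change 3-methoxyphenyl in place of 2,2-dimethyl-1,3-dioxolan-4-yl on a saturated chain carbon bound to an aromatic nitrogen has been made once before among these compounds, and it gave the step of an at least 8.3-fold higher number from compound 2 to compound 1 (0.92 log units; beyond the scatter), that is, toward weaker inhibition, running into the limit (the limit of > 100000 nM in this assay, at which 2 of the 3 values shown sit). Compound 4 `COc1ccc(C(O)c2cn(Cc3cccc(OC)c3)nn2)cc1` has not yet been measured; it differs from compound 3 by 3-methoxyphenyl in place of 2,2-dimethyl-1,3-dioxolan-4-yl on a saturated chain carbon bound to an aromatic nitrogen, the same change at the same place, while the difference between the two cores is not broken down here. Compound 3 already sits at a limit in this assay this assay, and the earlier step moved toward that same limit, so a number is not expected for compound 4 either. Compound 4 is estimated at 150000 nM, most likely reported again only as a limit, because the step of an at least 8.3-fold higher number from compound 2 to compound 1 (0.92 log units; beyond the scatter) ran toward the limit (the limit of > 100000 nM in this assay, at which 2 of the 3 values shown sit). The expected step is a step that the limit leaves unreadable from compound 3 to compound 4.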

Compound 4, half-maximal inhibitory concentration: > 100000 nM
Compound 4 was reported as a limit; the forecaster's own chance of this, stated with the estimate: 85%; the middle value lies beyond the limit too.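

Compound 3 and compound 4 both give a limit rather than a number, so no step between them can be read: the limit of > 100000 nM in this assay, at which 3 of the 4 values shown sit.

The compounds shown leave open whether 3-methoxyphenyl in place of 2,2-dimethyl-1,3-dioxolan-4-yl changes inhibition at all on the core of compound 3.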